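The source may hold more compounds than are shown below. What is called first, only, known or untested is meant among the compounds shown, and "the series" means these compounds.

Measured compounds:
Compound 1: `CCOC(=O)CCCCCOc1cccc(CN(C(=O)c2ccc(-c3cccc(-c4nnc(C)o4)c3)cc2)C(C)C)c1` — in an ADME assay on Raji cells (Homo sapiens) for cytotoxicity, read by CellTiter-Glo and resazurin assay, with a stated time of 72 h (a lower number here means that less compound is needed, a higher number that more compound is needed for the effect), compound 1 gives > 26000 nM, a limit of the assay rather than a number.
Compound 2: `CCOC(=O)CCCCCOc1cccc(CN(C(=O)c2ccc(-c3cc(OC)ccc3F)cc2)C(C)C)c1` — in this assay compound 2 gives > 26000 nM, again only a limit.

Compound 2 therefore stands at the upper edge of what this assay can report. The next compound, compound 3 `CCOC(=O)CCCCCOc1cccc(CN(C(=O)c2ccc(-c3cccc(Cl)c3)cc2)C(C)C)c1`, differs from compound 2 in one place: 3-chlorophenyl in place of 2-fluoro-5-methoxyphenyl on an aromatic carbon. Among the compounds with values here, the only measured step touching this position, a step that the two limits leave unreadable from compound 1 to compound 2, cannot be sized, since the limit of > 26000 nM in this assay, at which 2 of the 2 values shown sit, holds both values. With no readable step, compound 3 is expected to stay at that limit too, with a step that the limit leaves unreadable from compound 2 to compound 3 amounting to no change beyond the scatter; the estimate is 30000 nM (range 12000 nM to 100000 nM).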

Compound 3, half-maximal effective concentration: > 18400 nM
Compound 3: only a limit was reported (the forecaster's own chance of this, stated with the estimate: 80%); the middle value lies beyond the limit too.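

Compound 3 gives > 18400 nM, again a limit and not a number. Compound 1 and compound 2 also gave only limits, so the steps linking these three compounds cannot be read. The compounds shown leave open how strongly any of these three groups changes the concentration needed in this assay.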